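This account rests on a few compounds, and the source may have more. Where it says the series, first, only, none or still open, it means among the compounds named here.

Compound 1 `Cc1ccc(-c2nn(-c3ccc(F)cc3)cc2C(=O)Nc2ccc(C)c(S(=O)(=O)N3CCOCC3)c2)cc1`: 24.3 nM
Compound 2 `CCCCn1cc(C(=O)Nc2ccc(C)c(S(=O)(=O)N3CCOCC3)c2)c(-c2ccc(C)cc2)n1`: 52.5 nM
Compound 3 `Cc1ccc(-c2nn(Cc3ccc4ccccc4c3)cc2C(=O)Nc2ccc(C)c(S(=O)(=O)N3CCOCC3)c2)cc1`: 10.2 nM

All three were tested in an assay on isolated protein for antagonist activity at Bile acid receptor (Homo sapiens), read by TR-FRET, with a stated time of 20 min; a higher number here means a weaker inhibitor, a lower number a stronger inhibitor. Compound 3 holds the lowest number of the three, its nearest neighbour being compound 1, as shown by a 2.4-fold lower number from compound 1 to compound 3 (0.38 log units; beyond the scatter) and by a 5.1-fold lower number from compound 2 to compound 3 (0.71 log units; beyond the scatter).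

Compound 4 `Cc1ccc(-c2nn(CCCCO)cc2C(=O)Nc2ccc(C)c(S(=O)(=O)N3CCOCC3)c2)cc1` differs from compound 3 by 3-hydroxypropyl in place of naphthalen-2-yl on a saturated chain carbon bound to an aromatic nitrogen. The step that bears most on this is a 5.1-fold lower number from compound 2 to compound 3 (0.71 log units; beyond the scatter), since compound 2 carried propyl on that same saturated chain carbon; compound 4 carries 3-hydroxypropyl there, so close to the reverse is expected. The step of a 2.2-fold higher number from compound 1 to compound 2 (0.33 log units; beyond the scatter) points the same way, a chain giving a higher number than a ring on that nitrogen. Compound 4 is therefore expected to show a 4.4-fold higher number from compound 3 to compound 4 (0.64 log units; beyond the scatter). The estimate for compound 4 is 45 nM, within 18 nM to 120 nM.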

Compound 4, half-maximal inhibitory concentration: 130 nM
Estimate against measurement, compound 4: 2.9-fold (0.46 log units) below, outside the stated range (above it).
By their numbers in this assay, from the lowest: compound 3; then compound 1; then compound 2; then compound 4.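

Adding a hydroxy to the end of the butyl chain raises the number (a 2.5-fold higher number from compound 2 to compound 4 (0.39 log units; beyond the scatter)), so this position responds to a change at the far end of the chain, not only to a swap between chain and ring. The 4-hydroxybutyl compound also trails both ring-bearing groups: 4-fluorophenyl (a 5.3-fold higher number from compound 1 to compound 4 (0.73 log units; beyond the scatter)) and (naphthalen-2-yl)methyl (a 13-fold higher number from compound 3 to compound 4 (1.11 log units; beyond the scatter)), the latter being the largest step seen at this position. Nothing available explains the effect of the hydroxy. From the compounds shown here alone, whether an amine or a carboxylic acid at the chain end would behave like the hydroxy remains open.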